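Restoring a tertiary amide at the weakest compound

The compounds below may be only part of what the source reports. "The series", "measured", "known", "first", "only" and "open" are said of these compounds alone.

Compound 1 `CCN(CC)S(=O)(=O)c1ccc(S(=O)(=O)N2CCC[C@@H](C(=O)N3CCC(OC)CC3)C2)cc1` gives 50 nM
Compound 2 `CCN(CC)S(=O)(=O)c1ccc(S(=O)(=O)N2CCC[C@@H](C(=O)N3CCOCC3)C2)cc1` gives 160 nM
Compound 3 `CCN(CC)S(=O)(=O)c1ccc(S(=O)(=O)N2CCC[C@@H](C(=O)NC3CCOCC3)C2)cc1` gives 1350 nM

These values come from a functional assay on MIA PaCa-2 cells (Homo sapiens) for inhibition, read by MTT assay, with a stated time of 3 days (on this read-out higher numbers stand for weaker inhibition and lower numbers for stronger inhibition), where compound 3 has the highest number of the three and compound 2 lies nearest to it. The step to compound 4 `CCN(CC)S(=O)(=O)c1ccc(S(=O)(=O)N2CCC[C@@H](C(=O)N3CCC(F)(F)CC3)C2)cc1` puts 4,4-difluoropiperidin-1-yl in place of (oxan-4-yl)amino on a carbonyl carbon. The amide hydrogen of compound 3 is thereby lost, and compound 1 and compound 2 lack it too.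

Going by the values given here, two measured steps bear on this change when read in reverse: a 27-fold higher number from compound 1 to compound 3 (1.43 log units; beyond the scatter) and an 8.4-fold higher number from compound 2 to compound 3 (0.93 log units; beyond the scatter). Each brought in (oxan-4-yl)amino and each raised the number. The gap between the two groups it replaced is smaller: a 3.2-fold higher number from compound 1 to compound 2 (0.51 log units; beyond the scatter). Among the compounds with values here, no measured compound here carries fluorine, so the size of the step remains uncertain.

A modest to large step towards a lower number is expected: a 15-fold lower number from compound 3 to compound 4 (1.18 log units; beyond the scatter). For compound 4 the estimated value is 90 nM, with an expected range from 30 nM to 300 nM.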

Compound 4, half-maximal inhibitory concentration: 19 nM
Estimate against measurement, compound 4: 4.7-fold (0.68 log units) above, and the stated range ends above it.
By their numbers in this assay, from the lowest: compound 4; then compound 1; then compound 2; then compound 3.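

The step of a 71-fold lower number from compound 3 to compound 4 (1.85 log units; beyond the scatter) shows that, on this carbonyl carbon, a group without the amide hydrogen and without any ring oxygen can give the lowest number of the four. Compound 4 also goes beyond the two oxygen-bearing tertiary amides, with an 8.4-fold lower number from compound 2 to compound 4 (0.93 log units; beyond the scatter) and a 2.6-fold lower number from compound 1 to compound 4 (0.42 log units; beyond the scatter), so 4,4-difluoropiperidin-1-yl, with no hydrogen-bond acceptors counted, surpasses both morpholin-4-yl and 4-methoxypiperidin-1-yl here. Nothing available explains these differences in terms of any measured property.

The compounds shown leave open how plain piperidin-1-yl would stand, so the share of the two fluorine atoms in this result remains unsettled. Also open, going by these compounds, is whether (4,4-difluorocyclohexyl)amino, which keeps the amide hydrogen alongside the fluorine atoms, would give a number nearer compound 3 or compound 4.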